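Solubility notes: cyclopropyl for chloro on the shared core

The source may hold more compounds than are shown below. What is called first, only, known or untested is meant among the compounds shown, and "the series" means these compounds.

Measured compounds and values:
compound 1 `Cn1ncc2c(NC3(c4ccc(C(F)(F)F)cc4)CC3)nc(Cl)nc21` – 156000 nM
compound 2 `FC(F)(F)c1ccc(C2(Nc3nc(Cl)nc4[nH]ncc34)CC2)cc1` – 105000 nM
compound 3 `Cn1ncc2c(NCc3ccc(C(F)(F)F)cn3)nc(Cl)nc21` – 176000 nM

In a physicochemical assay for solubility, at pH 6.5 (a higher number here means a more soluble compound, a lower number a less soluble compound), compound 1 stands second highest of three numbers, with compound 3 nearest and compound 2 furthest, both within the scatter. Within the data shown here, the one measured step, a 1.5-fold lower number from compound 1 to compound 2 (0.17 log units; within the scatter), exchanges hydrogen for methyl on an aromatic nitrogen and lies within the scatter. Compound 4 `Cn1ncc2c(NC3(c4ccc(C(F)(F)F)cc4)CC3)nc(C3CC3)nc21` differs from compound 1 by cyclopropyl in place of chloro on an aromatic carbon. Among the measured compounds shown here, no measured step touches this position or this exchange, so nothing in the data sets its size. A small downward step is expected, a 1.7-fold lower number from compound 1 to compound 4 (0.24 log units; within the scatter), with wide uncertainty. For compound 4 in this assay the estimate is 90000 nM, expected to lie between 35000 nM and 230000 nM.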

Compound 4, solubility: 125000 nM
Estimate against measurement, compound 4: 1.4-fold (0.14 log units) below, within the range that was stated.
By their numbers in this assay, from the lowest: compounds 2, 4, 1 and 3 (each within the scatter of the next).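

At the aromatic carbon between two ring nitrogen atoms, the shared core now has its first reading in this assay: cyclopropyl in place of chloro gives a 1.2-fold lower number from compound 1 to compound 4 (0.10 log units; within the scatter) and so brings a three-membered non-aromatic ring onto this carbon with no change beyond the scatter. Nothing available gives a reason for this reading.

Going by these compounds, whether an amine or a methoxy group on this carbon would also stay within the scatter remains open. So does the size of the same exchange with hydrogen on the aromatic nitrogen, as in compound 2.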